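Moving a Methoxy Group Around the Ring of Compound 1

The compounds below may be only part of what the source reports. "The series", "measured", "known", "first", "only" and "open" are said of these compounds alone.

Compound 1 `COc1ccccc1/C=C/C(=O)OC/C=C/c1cc(OC)c(OC)cc1OC` is a cinnamate ester carrying a 2-methoxyphenyl group. In a functional assay on the whole organism (strain Kunming) with Mus musculus as the target, with a stated time of 0.5 h, at a dose of 300 mg/kg by the intraperitoneal route (on this read-out lower numbers stand for a stronger effect and higher numbers for a weaker effect at the one dose given), compound 1 gives 100%. Two close relatives have been tested in the same way. Compound 2 `COc1cc(OC)c(OC)cc1/C=C/COC(=O)/C=C/c1ccc(Br)cc1` carries a 4-bromophenyl group instead, and in this assay compound 2 gives 100%. Compound 3 `COc1cc(OC)c(OC)cc1/C=C/COC(=O)/C=C/c1ccccc1Cl` carries a 2-chlorophenyl group, and in this assay compound 3 gives 100%. So compound 1 stands level with compound 2 and compound 3 on the numbers in hand.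

The three steps among the measured compounds tell the same story. The step of no change at the digits printed from compound 1 to compound 2 (within the scatter), the step of no change at the digits printed from compound 1 to compound 3 (within the scatter) and the step of no change at the digits printed from compound 2 to compound 3 (within the scatter) each show no movement beyond the scatter, even though the group on the double-bonded chain carbon changes considerably each time.

Compound 4 `COc1ccc(/C=C/C(=O)OC/C=C/c2cc(OC)c(OC)cc2OC)cc1` is the untested partner. The change from compound 1 is 4-methoxyphenyl in place of 2-methoxyphenyl on a double-bonded chain carbon bound to a double-bonded chain carbon. Because the step of no change at the digits printed from compound 1 to compound 2 (within the scatter) and the step of no change at the digits printed from compound 1 to compound 3 (within the scatter) were both flat, this step is expected to be flat too, and the estimated step of no change at the digits printed from compound 1 to compound 4 (within the scatter) reflects that. For compound 4 in this assay the expected value is 100%, within a range from 85% to 100%.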

Compound 4, a percentage reported as activity, at one dose (the size of the read-out at that dose, not a potency): 100%
For compound 4 middle estimate and measured number coincide at the digits printed, and the stated range covers the measured number.
By their numbers in this assay, from the lowest: compounds 1, 2, 3 and 4 (each within the scatter of the next).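

Moving the methoxy group is the new element here: 4-methoxyphenyl in place of 2-methoxyphenyl on a double-bonded chain carbon bound to a double-bonded chain carbon keeps the same atoms joined differently, and in this assay this gives (no change at the digits printed from compound 1 to compound 4 (within the scatter)). The earlier steps shown here all swapped one group for a different one, so this pair adds that the location of the methoxy group, as well as the identity of the group, leaves the number within the scatter in this set, and the comparisons with the halogen-bearing relatives agree, with (no change at the digits printed from compound 3 to compound 4 (within the scatter)) for 4-methoxyphenyl in place of 2-chlorophenyl and (no change at the digits printed from compound 2 to compound 4 (within the scatter)) for methoxy in place of bromo on an aromatic carbon. No measurement in hand offers an explanation for this flat picture.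

As far as these compounds go, all four compounds carry a phenyl group with a single methoxy, chloro or bromo group at this place, so it stays open whether an amine or a carboxylic acid on that ring, or a longer chain in its place, would shift the number away from this shared level. From the compounds shown here alone, it also stays open whether changes to the shared core would do so.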